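This account rests on a few compounds, and the source may have more. Where it says the series, first, only, none or still open, it means among the compounds named here.

Measured compounds in an in vitro ADME assay on microsomes from liver (Homo sapiens) for metabolic stability, read by LC-MS, using NADPH, tested at 1 uM; a higher number here means that the compound lasts longer, a lower number that the compound disappears faster:
- compound 1 `CCN1C(=O)CN(Cc2ccc(-c3cccc(CN4CCCCC4)n3)cc2)C1=O` gives 2 h
- compound 2 `CN1C(=O)CN(Cc2ccc(-c3cccc(CN4CCCCC4)n3)cc2)C1=O` gives 1.83 h
- compound 3 `CC(C)N1C(=O)CN(Cc2ccc(-c3cccc(CN4CCCCC4)n3)cc2)C1=O` gives 1.35 h

Compound 1 holds the highest of the three numbers in this assay, but only by margins inside the scatter: a 1.1-fold lower number from compound 1 to compound 2 (0.04 log units; within the scatter) and a 1.5-fold lower number from compound 1 to compound 3 (0.17 log units; within the scatter), with a 1.4-fold lower number from compound 2 to compound 3 (0.13 log units; within the scatter) between the other two. The three compounds are therefore indistinguishable on half-life.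

Compound 4 `CCN1C(=O)CN(Cc2ccc(-c3cccc(CC4CCCCC4)n3)cc2)C1=O` differs from compound 1 at the other end of the shared core: cyclohexyl in place of piperidin-1-yl on a saturated chain carbon bound to an aromatic carbon. Within the data shown here, none of the measured steps touches this place; all three vary the group on the amide-type nitrogen in the ring, and all three stay within the scatter. Among the measured compounds shown here, there is thus no measured step that bears on the change from compound 1 to compound 4, and nothing points to a step beyond the scatter in either direction.

For the measured compounds named here, the half-life of compound 4 in this assay is therefore estimated at 2 h (range 0.7 h to 6 h), which means an expected step of no change at the digits printed from compound 1 to compound 4 (within the scatter), with the range kept wide since no measured pair covers this change.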

Compound 4, half-life: 0.667 h
The estimate for compound 4 lay 3.0-fold (0.48 log units) above the measured number, outside the stated range (below it).
By their numbers in this assay, from the lowest: compound 4; then compounds 3, 2 and 1 (each within the scatter of the next).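

In this assay, among these compounds, cyclohexyl in place of piperidin-1-yl on a saturated chain carbon bound to an aromatic carbon gives a 3.0-fold lower number from compound 1 to compound 4 (0.48 log units; beyond the scatter) as the first step beyond the scatter. The half-life therefore responds at this place, whereas the changes on the amide-type nitrogen in the ring all stayed within the scatter. The change keeps the six-membered ring and the count of heavy atoms but takes out the ring nitrogen and its hydrogen-bond acceptor, and nothing measured here explains the step.

Still open, going by these compounds, is whether the step is tied to the ring nitrogen or would also appear with other groups at this place, such as morpholin-4-yl or an open-chain diethylamine. Also open, on these data alone, is whether it carries over to the methyl and isopropyl counterparts on the amide-type nitrogen.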